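A few compounds are considered here, and "the series" means these few. Any claim that something is new, unique, unknown or untested is made for them only; others in the source may bear on it.

Measured compounds:
Compound 1, `CCn1c([C@@H](C)NS(=O)(=O)c2ccc(Cl)cc2)nc2cc(C#N)ccc21`: 71 mL.min-1.g-1
Compound 2, `CCn1c([C@@H](C)NS(=O)(=O)c2ccc(Cl)cc2)nc2cc(C(N)=O)ccc21`: < 5 mL.min-1.g-1
Compound 3, `CCn1c([C@@H](C)NS(=O)(=O)c2ccccc2)nc2ccc(C(F)(F)F)cc21`: 14 mL.min-1.g-1

In an ADME assay (liver) for metabolic stability, with Liver microsome (Homo sapiens) as the target, read by LC-MS, using microsomes and NADPH, with a stated time of 5 min, at 37 degrees C (a lower number here means slower removal, a higher number faster removal of the compound), compound 1 gives 71 mL.min-1.g-1. Compound 2 gives only a limit of the assay, < 5 mL.min-1.g-1, which is no exact number; it sits at the limit of < 5 mL.min-1.g-1 in this assay, at which 1 of the 3 values shown sits. Among the compounds with values here, the one measured step, an at least 14-fold lower number from compound 1 to compound 2 (1.15 log units; beyond the scatter), is large but concerns a carbamoyl for a cyano on an aromatic carbon of the shared core. Compound 3 has the lowest of the two exact numbers, and its gap to compound 1 lies beyond the usual scatter.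

Compound 4, `CCn1ncc(S(=O)(=O)N[C@H](C)c2nc3ccc(C(F)(F)F)cc3n2CC)c1C`, is not yet measured. It differs from compound 3 by 1-ethyl-5-methyl-1H-pyrazol-4-yl in place of phenyl on a sulfonyl sulfur. Within the data shown here, no measured step changes the group on the sulfonyl sulfur, so the step from compound 1 to compound 2 gives no direct guide here, and nothing among the measured compounds points to a particular direction. For compound 4 the number in this assay is therefore expected to stay close to that of compound 3, with the step of a 1.4-fold lower number from compound 3 to compound 4 (0.15 log units; within the scatter) expected to lie within or only slightly beyond the scatter. The estimate for compound 4 is 10 mL.min-1.g-1, with a range from 4 mL.min-1.g-1 to 30 mL.min-1.g-1.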

Compound 4, intrinsic clearance in microsomes: > 100 mL.min-1.g-1
Compound 4: a limit, no number; the forecaster's own chance of this, stated with the estimate: 25%; at least 10-fold (1.00 log units) between middle value and limit.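

Within the data shown here, until now, the only measured step changed a group on the shared core, so nothing showed how this assay responds to a change on the sulfonyl sulfur. Compound 4 gives only a limit of the assay, not an exact number: the limit of > 100 mL.min-1.g-1 in this assay, at which 1 of the 4 values shown sits. Placing 1-ethyl-5-methyl-1H-pyrazol-4-yl in place of phenyl on a sulfonyl sulfur gives an at least 7.1-fold higher number from compound 3 to compound 4 (0.85 log units; beyond the scatter), which shows that this position can strongly change the read-out and that this particular exchange moves it towards faster removal, the opposite direction to the one earlier step.

The compounds shown cannot separate the contributions of the parts of the new group, such as its ring, its ethyl chain and its methyl group, and the limit leaves the full size of the step unknown. A pyrazol-4-yl ring with a methyl group in place of the ethyl chain, a ring without either chain, or a pyridyl ring on the same sulfur would help show which part of the exchange matters, and a carbamoyl group on the core of compound 4 would test whether the earlier step carries over.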